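Working notes: the step from compound 3 to compound 4

The source may report more compounds than this note shows. Statements on the series, on what has been measured and on what is new or still open speak of the compounds shown alone.

Values in an ADME assay on Vero cells (Chlorocebus sabaeus) for cytotoxicity, read by resazurin assay, with a stated time of 72 h; on this read-out higher numbers stand for weaker inhibition and lower numbers for stronger inhibition:
- compound 1 `Cc1ccc(C(=O)CCN2CCN(c3ccc([N+](=O)[O-])cc3)CC2)cc1`: 235000 nM
- compound 2 `O=C(CCN1CCN(c2ccc([N+](=O)[O-])cc2)CC1)c1ccc(F)c(F)c1`: 122000 nM
- compound 3 `O=C(CCN1CCN(c2ccc(F)cc2)CC1)c1ccc(Cl)c(F)c1`: 105000 nM
- compound 4 `O=C(CCN1CCN(c2ccc([N+](=O)[O-])cc2)CC1)c1ccc(Cl)c(F)c1`: not yet measured

In this assay compound 3 gives 105000 nM, within the scatter of compound 2 at 122000 nM. Compound 1, at 235000 nM, shows a higher number than compound 3, and that gap lies beyond the scatter.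

The change to be followed is nitro in place of fluoro on an aromatic carbon, read in short as 4-fluorophenyl to 4-nitrophenyl. Within the data shown here, no measured step isolates this swap. Among the measured compounds shown here, the only measured step, a 1.9-fold lower number from compound 1 to compound 2 (0.28 log units; within the scatter), keeps the 4-nitrophenyl group on both sides and alters another part of the molecule, so it bears on the question only indirectly. For the measured compounds named here, it does show no change beyond the scatter among the nitro compounds measured so far.

The expected change is a 1.2-fold higher number from compound 3 to compound 4 (0.08 log units; within the scatter), so no step beyond the scatter is anticipated. Compound 4 is estimated at 125000 nM, with an expected range of 65000 nM to 240000 nM.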

Compound 4, half-maximal inhibitory concentration: 89200 nM
For compound 4 the middle estimate is 1.4-fold (0.15 log units) above the measured one; the measured number falls inside the stated range.
By their numbers in this assay, from the lowest: compounds 4, 3, 2 and 1 (each within the scatter of the next, the first and the last beyond it).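

In this assay nitro in place of fluoro on an aromatic carbon can now be read directly, with the 4-chloro-3-fluorophenyl group held constant, and it gives a 1.2-fold lower number from compound 3 to compound 4 (0.07 log units; within the scatter) so the swap leaves the number within the scatter. Among these compounds, with the 4-nitrophenyl group held constant, chloro in place of fluoro gives a 1.4-fold lower number from compound 2 to compound 4 (0.14 log units; within the scatter) while the 4-chloro-3-fluorophenyl group in place of 4-methylphenyl on the carbonyl carbon gives a 2.6-fold lower number from compound 1 to compound 4 (0.42 log units; beyond the scatter) which is the only step here beyond the scatter. Nothing available explains why these steps have the sizes they do.

On these data alone, whether an amine or a carboxylic acid on the same aromatic carbon would also stay within the scatter remains open. Also open, as far as these compounds go, is whether the nitro and fluoro groups would remain interchangeable in this assay with 4-methylphenyl on the carbonyl carbon.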